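Adding methoxy groups to the chalcone ring of compound 2

The source may hold more compounds than are shown below. What is called first, only, known or untested is meant among the compounds shown, and "the series" means these compounds.

Of the compounds shown here, three sharing one core have been tested in a functional assay on MDA-MB-231 cells (Homo sapiens) for antiproliferative activity, read by MTT assay, with a stated time of 24 h; a lower number here means a stronger inhibitor, a higher number a weaker inhibitor. Compound 1 `COc1ccc(C(=O)/C=C/c2cc(-c3cc(OC)c(OC)c(OC)c3)n3nc(-c4ccccc4)cc3n2)cc1` gives 13200 nM. Compound 2 `COc1ccc(/C=C/C(=O)c2cc(-c3cc(OC)c(OC)c(OC)c3)n3nc(-c4ccccc4)cc3n2)cc1` gives 16500 nM, and compound 3 `COc1cc(-c2cc(/C=C/C(=O)c3ccc(Cl)cc3)nc3cc(-c4ccccc4)nn23)cc(OC)c1OC` gives 32500 nM. Compound 2 thus holds the second highest number of the three, with compound 1 at a 1.3-fold higher number from compound 1 to compound 2 (0.10 log units; within the scatter) and compound 3 at a 2.0-fold higher number from compound 2 to compound 3 (0.29 log units; within the scatter).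

Compound 4 `COc1cc(/C=C/C(=O)c2cc(-c3cc(OC)c(OC)c(OC)c3)n3nc(-c4ccccc4)cc3n2)cc(OC)c1OC` differs from compound 2 in one place: 3,4,5-trimethoxyphenyl in place of 4-methoxyphenyl on a double-bonded chain carbon bound to a double-bonded chain carbon. Within the data shown here, no measured step adds methoxy groups to this ring. The closest hint is the swap on the ring at the other end of the chain, where a 2.5-fold higher number from compound 1 to compound 3 (0.39 log units; beyond the scatter) shows that changing a methoxy to a chloro moved the number only modestly. A change in substitution on an aromatic ring is therefore expected to give a small step in this assay, if any, with no clear direction.

The expected step is a 1.2-fold lower number from compound 2 to compound 4 (0.07 log units; within the scatter), and compound 4 is estimated at 14000 nM, within a range of 6000 nM to 35000 nM.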

Compound 4, half-maximal inhibitory concentration: 18400 nM
Beside the measured number, compound 4's estimate is 1.3-fold (0.12 log units) below it; low and high end bracket the measured number.
By their numbers in this assay, from the lowest: compounds 1, 2, 4 and 3 (each within the scatter of the next, the first and the last beyond it).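

Replacing 4-methoxyphenyl with 3,4,5-trimethoxyphenyl on a double-bonded chain carbon bound to a double-bonded chain carbon gives a 1.1-fold higher number from compound 2 to compound 4 (0.05 log units; within the scatter) in this assay and so shows that this position accepts a group of 12 heavy atoms in place of one of 8 with no change beyond the scatter. Among these compounds, the earlier steps did not vary the substituents on this ring, so this is the first direct reading of the position. No measurement shown here accounts for the added methoxy groups leaving the number within the scatter.

From the compounds shown here alone, what would happen with a quite different group on this ring remains open, for example a dimethylamino group or a carboxylic acid. Whether a plain phenyl ring with no methoxy group would stay within the scatter of compound 2 is also unanswered.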